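A few compounds are considered here, and "the series" means these few. Any claim that something is new, unique, unknown or untested is made for them only; others in the source may bear on it.

Compound 3 `N[C@H]1CC[C@H](Nc2c(C(=O)NCc3ccc(F)cc3)nc(Br)c3cccnc23)CC1` carries a 4-aminocyclohexyl group on the nitrogen on the aromatic ring of the shared core. In a functional assay on LNCaP cells (Homo sapiens) for cytotoxicity, read by MTT assay, with a stated time of 72 h (a lower number here means a stronger inhibitor, a higher number a weaker inhibitor), compound 3 gives 5000 nM. Its closest measured neighbour is compound 1 `Nc1cccc(Nc2c(C(=O)NCc3ccc(F)cc3)nc(Br)c3cccnc23)c1`, which carries a 3-aminophenyl group at the same place; in this assay compound 1 gives 8000 nM. The step from the aromatic to the saturated ring is a 1.6-fold lower number from compound 1 to compound 3 (0.20 log units; within the scatter), so the two numbers cannot be told apart. A third compound, compound 2 `NCCCNc1c(C(=O)NCc2ccc(F)cc2)nc(Br)c2cccnc12`, in this assay gives "not determined" (no result reported), so no number is available for it.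

Compound 4 `CNCCCNc1c(C(=O)NCc2ccc(F)cc2)nc(Br)c2cccnc12` differs from compound 3 in a single place: 3-(methylamino)propyl in place of 4-aminocyclohexyl on a nitrogen on an aromatic ring. Among the measured compounds shown here, no measured pair here matches an open chain against a ring, so the only guidance is indirect. For the measured compounds named here, the one step that exists, a 1.6-fold lower number from compound 1 to compound 3 (0.20 log units; within the scatter), shows that exchanging one ring for another at this nitrogen left the number where it was. Compound 2, the closest analogue of compound 4, gives no number to lean on. The account therefore expects compound 4 to stay near compound 3, with a 1.2-fold higher number from compound 3 to compound 4 (0.08 log units; within the scatter) a step of the kind that would not stand out. For compound 4 the estimate in this assay is 6000 nM, with a range from 2000 nM to 20000 nM.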

Compound 4, half-maximal inhibitory concentration: 8000 nM
Beside the measured number, compound 4's estimate is 1.3-fold (0.12 log units) below it, and the stated range covers the measured number.
By their numbers in this assay, from the lowest: compounds 3, 1 and 4 (each within the scatter of the next).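

Among the compounds shown here, compound 4 gives the first measured number for an open chain at this nitrogen on an aromatic ring. In this assay, replacing the 4-aminocyclohexyl group with 3-(methylamino)propyl gives a 1.6-fold higher number from compound 3 to compound 4 (0.20 log units; within the scatter), and replacing the 3-aminophenyl group with the same chain gives no change at the digits printed from compound 1 to compound 4 (within the scatter). For the compounds shown here, the earlier step compared only two rings, whereas these steps show that, across these three compounds, the numbers for an aromatic ring, a saturated ring and an open chain cannot be told apart, even though the chain has no ring and none of the 2 defined stereocentres of the 4-aminocyclohexyl group; no supporting measurement speaks to why these numbers lie so close together.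

All three groups carry an amine, so the compounds shown leave open whether a plain propyl chain without an amine, a carboxylic acid in its place or a longer chain bearing the amine would give a step beyond the scatter at this nitrogen. Because the rest of the shared core stays the same throughout, they also leave open how much the number depends on that remaining structure.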